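Side-chain swap at the shared core: compound 3 to compound 4

The compounds below may be only part of what the source reports. "The series", "measured", "known", "first", "only" and "open" are said of these compounds alone.

Compound 1 `O=C(O)c1ccccc1-c1ccc(CCc2ncc(C3CCCCC3)[nH]2)cc1` gives 375 nM in an in vitro functional assay on cells for agonist activity at Bombesin receptor subtype-3 (Homo sapiens), read by luminescence and calcium flux; a lower number here means that less compound is needed, a higher number that more compound is needed for the effect.
Compound 2 `COc1ccc(Cc2cnc(CCc3ccc(-c4ccccc4C(=O)O)cc3)[nH]2)cc1` gives 5360 nM in this assay.
Compound 3 `O=C(O)c1ccccc1-c1ccc(CCc2ncc(CCC3CCCCC3)[nH]2)cc1` gives 642 nM in this assay.

Compound 3 holds the second highest of the three numbers. The near gap is small: a 1.7-fold higher number from compound 1 to compound 3 (0.23 log units; within the scatter). The far gap is larger: an 8.3-fold lower number from compound 2 to compound 3 (0.92 log units; beyond the scatter).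

Compound 4 `O=C(O)c1ccccc1-c1ccc(CCc2ncc(Cc3ccc(F)cc3)[nH]2)cc1` differs from compound 3 by 4-fluorophenyl in place of cyclohexylmethyl on a saturated chain carbon bound to an aromatic carbon. This move runs close to the reverse of the step seen as an 8.3-fold lower number from compound 2 to compound 3 (0.92 log units; beyond the scatter), and a 14-fold higher number from compound 1 to compound 2 (1.16 log units; beyond the scatter) points the same way; both steps lie beyond the scatter. In this assay compound 4 is therefore expected to give a modestly higher number, about a 4.7-fold higher number from compound 3 to compound 4 (0.67 log units; beyond the scatter). The estimate for compound 4 is 3000 nM, with a range of 1000 nM to 10000 nM.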

Compound 4, half-maximal effective concentration: 1600 nM
For compound 4 the middle estimate is 1.9-fold (0.27 log units) above the measured one; low and high end bracket the measured number.
By their numbers in this assay, from the lowest: compounds 1 and 3 (each within the scatter of the next); then compound 4; then compound 2.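

The benzyl series is sensitive to what the aromatic ring carries: fluoro in place of methoxy gives a 3.4-fold lower number from compound 2 to compound 4 (0.53 log units; beyond the scatter). Even so, the aromatic ring of compound 4 does not match either saturated ring, with a 2.5-fold higher number from compound 3 to compound 4 (0.40 log units; beyond the scatter) and a 4.3-fold higher number from compound 1 to compound 4 (0.63 log units; beyond the scatter). Among these four compounds, both 4-substituted benzyl groups thus give higher numbers than both cyclohexyl-bearing groups, with no exception.

No supporting data bear on why these gaps arise. Open, as far as these compounds go, is whether unsubstituted benzyl, cyclohexylmethyl or a chloro or hydroxyl group on the benzyl ring would narrow the gap to compound 1.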